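A few compounds are considered here, and "the series" means these few. Any claim that something is new, unique, unknown or untested is made for them only; others in the source may bear on it.

Three compounds share one core and differ only in the group attached to the outer sulfur of the disulfide. Compound 1, `Cc1cn([C@H]2C[C@H](SSc3ccccc3[N+](=O)[O-])[C@@H](CO)O2)c(=O)[nH]c1=O`, carries a 2-nitrophenyl there and gives 31000 nM in a functional assay on MOLT-4 cells (Homo sapiens) for cytotoxicity; on this read-out higher numbers stand for weaker inhibition and lower numbers for stronger inhibition. Compound 2, `Cc1cn([C@H]2C[C@H](SSc3ccc([N+](=O)[O-])cc3)[C@@H](CO)O2)c(=O)[nH]c1=O`, carries a 4-nitrophenyl and in this assay compound 2 gives 29000 nM. Compound 3, `CCCCCCCCSS[C@H]1C[C@H](n2cc(C)c(=O)[nH]c2=O)O[C@@H]1CO`, carries an octyl chain, and in this assay compound 3 gives 26000 nM. Compound 3 thus has the smallest of the three numbers, but a 1.2-fold lower number from compound 1 to compound 3 (0.08 log units; within the scatter) and a 1.1-fold lower number from compound 2 to compound 3 (0.05 log units; within the scatter) show that its gaps to the other two fall within the scatter, as does a 1.1-fold lower number from compound 1 to compound 2 (0.03 log units; within the scatter), so the three sit together.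

Compound 4, `Cc1cn([C@H]2C[C@H](SSCCCCCCO)[C@@H](CO)O2)c(=O)[nH]c1=O`, is compound 3 with hydroxy in place of ethyl on a saturated chain carbon, six bonds along the chain from a sulfur. Going by the values given here, no measured step touches the far end of this chain, but the whole exchange of the sulfur group between compound 1, compound 2 and compound 3 moved the number only within the scatter. A change confined to the chain end is therefore expected to give no step beyond the scatter, and compound 4 is estimated at 28000 nM, with a range from 14000 nM to 56000 nM, which means an expected step of a 1.1-fold higher number from compound 3 to compound 4 (0.03 log units; within the scatter).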

Compound 4, half-maximal inhibitory concentration: 42000 nM
For compound 4 the middle estimate is 1.5-fold (0.18 log units) below the measured one; low and high end bracket the measured number.
By their numbers in this assay, from the lowest: compounds 3, 2, 1 and 4 (each within the scatter of the next).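

Placing hydroxy at the chain end, six bonds along the chain from a sulfur, adds a hydrogen-bond donor and acceptor where the earlier compounds had none, yet in this assay the result is a 1.6-fold higher number from compound 3 to compound 4 (0.21 log units; within the scatter) and so stays within the scatter. The comparisons with the two nitrophenyl compounds read the same way, with a 1.4-fold higher number from compound 2 to compound 4 (0.16 log units; within the scatter) and a 1.4-fold higher number from compound 1 to compound 4 (0.13 log units; within the scatter) both within the scatter, so across these four compounds neither the chain end nor the whole group on the outer sulfur shows a step beyond it. Nothing measured here offers an explanation for these small steps.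

The compounds shown leave open whether any group at this chain end can move the number beyond the scatter. An amine or a carboxylic acid in place of the hydroxy, or a longer chain than octyl, would put that question to the test.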